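A Solubility Step Hidden Behind an Assay Limit

The compounds below may be only part of what the source reports. "The series", "measured", "known", "first", "only" and "open" are said of these compounds alone.

In a physicochemical assay for solubility, at pH 7.4 (a higher number here means a more soluble compound, a lower number a less soluble compound), compound 2 `C=CC(=O)Nc1ccc(F)c(-n2c(-c3nc(-c4cnn(C5CCN(C)CC5)c4)cnc3N)nc3ccccc32)c1` gives < 10000 nM, which is a limit and not a number. Compound 1 `C=CC(=O)Nc1cccc(-n2c(-c3nc(-c4cnn(C5CCN(C)CC5)c4)cnc3N)nc3ccccc32)c1` gives < 10000 nM, also a limit. Compound 3 `C=CC(=O)Nc1cc(-n2c(-c3nc(-c4cnn(C5CCN(C)CC5)c4)cnc3N)nc3ccccc32)ccc1OC` gives < 10000 nM, again a limit. The evidence so far is thus (the limit of < 10000 nM in this assay, at which 3 of the 3 values shown sit).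

Compound 4 `C=CC(=O)Nc1ccccc1Cn1c(-c2nc(-c3cnn(C4CCN(C)CC4)c3)cnc2N)nc2ccccc21` carries 2-((vinylcarbonyl)amino)benzyl in place of 2-fluoro-5-((vinylcarbonyl)amino)phenyl on an aromatic nitrogen.

Neither a step that the two limits leave unreadable from compound 1 to compound 2 nor a step that the two limits leave unreadable from compound 1 to compound 3 gives a size to carry over, so no change beyond the scatter is expected in this assay, in either direction. The expected size is a step that the limit leaves unreadable from compound 2 to compound 4. Compound 4 is expected at 6000 nM, with an estimated range from 1500 nM to 12000 nM.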

Compound 4, solubility: 35000 nM
Estimate against measurement, compound 4: 5.8-fold (0.77 log units) below; the whole stated range lies below it.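

The position on the aromatic nitrogen now shows a readable response in this assay: 2-((vinylcarbonyl)amino)benzyl in place of 2-fluoro-5-((vinylcarbonyl)amino)phenyl gives an at least 3.5-fold higher number from compound 2 to compound 4 (0.54 log units; beyond the scatter). The same group in place of 3-((vinylcarbonyl)amino)phenyl gives an at least 3.5-fold higher number from compound 1 to compound 4 (0.54 log units; beyond the scatter). The steps among the earlier compounds cannot be read, and they rest on one limit: the limit of < 10000 nM in this assay, at which 3 of the 4 values shown sit.

Each readable step changes both the group's link to the nitrogen and the place of its vinylcarbonylamino part, and the compounds shown do not separate the two. Also open, from the compounds shown here alone, is how an amine on the benzyl ring, or a longer chain in place of the benzyl link, would read.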